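Methyl on the Phenyl Ring of Compound 2

The source may report more compounds than this note shows. Statements on the series, on what has been measured and on what is new or still open speak of the compounds shown alone.

Compound 2 `O=C1c2ccc(C#Cc3ccccc3)nc2CCN1C1CCCC1` gives 5.9 nM in a functional assay on HEK293 cells for positive allosteric modulation of metabotropic glutamate receptor 5 (Homo sapiens), read by FLIPR and calcium flux; a higher number here means that more compound is needed for the effect, a lower number that less compound is needed. That is the only number shown for the series; compound 1 `CC(C)N1CCc2nc(C#Cc3cccnc3)ccc2C1=O` is reported as "not active" (no number reported) in this assay without a number, so no step between two measured compounds is available. Compound 3 `Cc1ccc(C#Cc2ccc3c(n2)CCN(C2CCCC2)C3=O)cc1` is not yet measured. It differs from compound 2 in one place: methyl in place of hydrogen on an aromatic carbon, on an aromatic carbon of a six-membered aromatic ring of carbon only, para to a large group; cut one bond further out, the change reads phenyl to 4-methylphenyl. Among the compounds with values here, with no measured step to lean on, the expectation for this change is a small shift toward more compound being needed in this assay, hardly beyond the scatter. Compound 3 is therefore expected to give 12 nM in this assay, with a range from 3 nM to 50 nM. The estimated step of a 2.0-fold higher number from compound 2 to compound 3 (0.31 log units; beyond the scatter) expresses that shift.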

Compound 3, half-maximal effective concentration: 4820 nM
The estimate for compound 3 lay 400-fold (2.60 log units) below the measured number; measured number outside the range, above it.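

Read in this assay, the step of an 820-fold higher number from compound 2 to compound 3 (2.91 log units; beyond the scatter) is the first measured in the series, and it shows how sensitive this place is: on the six-membered aromatic ring of carbon only, para to a large group, the change from phenyl to 4-methylphenyl is enough to cause a large rise in the number. A single methyl, with 1 heavy atom, therefore separates a low-nanomolar compound from a far weaker one, which the lone value of compound 2 could not reveal, and compound 1 cannot be used as a comparison since it differs from compound 2 in more than one place. No measurement at hand bears on the reason for this step.

From the compounds shown here alone, it remains open whether a smaller atom such as fluorine or a different group such as methoxy at this carbon would be accepted. Going by these compounds, it also remains open whether methyl on another carbon of the phenyl ring would produce a step of similar size.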